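The compounds below may be only part of what the source reports. "The series", "measured", "known", "first", "only" and "open" are said of these compounds alone.

Of the compounds shown here, three that share a core have been tested in a functional assay on HEK293 cells for agonist activity at D(4) dopamine receptor (Homo sapiens), read by FLIPR; a lower number here means that less compound is needed, a higher number that more compound is needed for the effect. Compound 1 `Cc1cccc(NC(=O)CN2CCC(c3ccc(O)cc3)CC2)c1` gives 70 nM. Compound 3 `Cc1cccc(NC(=O)CN2CCC(c3cccc(C#N)n3)CC2)c1` differs from it only on a saturated ring carbon, and the step of a 1.9-fold lower number from compound 1 to compound 3 (0.29 log units; within the scatter) stays within the scatter. Among the compounds with values here, compound 2 `Cc1cc(C(=O)NCN2CCC(c3cccc[n+]3[O-])CC2)ccc1F` gives 50 nM; this number is within the scatter of compound 3 at 36 nM and also within the scatter of compound 1, so the three compounds cannot be told apart on the numbers measured so far.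

Compound 4 `O=C(NCN1CCC(c2cccc[n+]2[O-])CC1)c1ccc(F)c(Cl)c1` has not yet been measured. It differs from compound 2 in a single place: chloro in place of methyl on an aromatic carbon. Within the data shown here, no measured step touches this part of the molecule; the only measured step, a 1.9-fold lower number from compound 1 to compound 3 (0.29 log units; within the scatter), concerns a group on a saturated ring carbon and was itself within the scatter. There is thus nothing in the data to suggest a movement beyond the scatter in this assay in either direction. The step of no change at the digits printed from compound 2 to compound 4 (within the scatter) is accordingly expected to be small. As far as these compounds go, for compound 4 the estimate is 50 nM, with a range from 20 nM to 125 nM that is kept wide because the change itself is untested.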

Compound 4, half-maximal effective concentration: 63 nM
For compound 4 the middle estimate is 1.3-fold (0.10 log units) below the measured one; measured number inside the range.
By their numbers in this assay, from the lowest: compounds 3, 2, 4 and 1 (each within the scatter of the next).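

Among the compounds shown, this is the only change on the aromatic carbon ortho to a fluoro group and meta to a large group, and in this assay chloro in place of methyl gives a 1.3-fold higher number from compound 2 to compound 4 (0.10 log units; within the scatter) and so no movement that can be told from ordinary repeat variation. The 4-fluoro-3-methylphenyl and 3-chloro-4-fluorophenyl versions therefore cannot be told apart in this assay, so this one-atom exchange, which adds no hydrogen-bond donor, acceptor or net charge, is tolerated at this position on this core. No supporting measurement is available to explain the result or to show how the two groups differ in other respects.

As far as these compounds go, whether this carbon remains equally undemanding with a different kind of group, such as a methoxy group, an amine, a carboxylic acid or a longer chain, remains open. Also open, from the compounds shown here alone, is whether chloro in place of methyl would read the same on the core of compound 1, which likewise carries a methyl on an aromatic carbon.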